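The source may report more compounds than this note shows. Statements on the series, on what has been measured and on what is new or still open speak of the compounds shown alone.

Of the compounds shown here, two have numbers so far. In an in vitro ADME assay on microsomes (Homo sapiens) for metabolic stability (a higher number here means that the compound lasts longer, a lower number that the compound disappears faster), compound 1 (`CCc1nc(-c2ccc(Cl)cc2Cl)c(CC)nc1CC(CC)CC`) gives 0.217 h as its half-life. Among the measured compounds shown here, compound 2 (`CCc1nc(-c2ccc(OC)cc2C(F)(F)F)c(CC)nc1NC(CC)CC`) gives 0.2 h in this assay and lies within the usual scatter of compound 1, so compound 1 stands level with the only other measured member of the series.

Compound 3 (`CCc1nc(-c2ccc(Cl)cc2Cl)c(CC)nc1NC(CC)CC`) keeps the core of compound 1 and its 2,4-dichlorophenyl group, with one change: (pentan-3-yl)amino in place of 2-ethylbutyl on an aromatic carbon, next to the ring nitrogen. For the measured compounds named here, no measured pair shows this change alone. Going by the values given here, compound 2 already carries (pentan-3-yl)amino, though with a different substituted phenyl group, and its 0.2 h half-life gives the only indirect guide. On that basis, no step beyond the scatter is expected, and no direction can be called. The expected outcome is a 1.1-fold lower number from compound 1 to compound 3 (0.04 log units; within the scatter) and remains within the scatter. For compound 3 the estimated half-life is 0.2 h with an expected range of 0.1 h to 0.4 h on repeat measurement.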

Compound 3, half-life: 0.283 h
Compound 3: the middle estimate sits 1.4-fold (0.15 log units) below what was measured; the measured number falls inside the stated range.
By their numbers in this assay, from the lowest: compounds 2, 1 and 3 (each within the scatter of the next).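

Among the compounds shown here, compound 1 and compound 3 form the first pair that differs in one place: with the core and the 2,4-dichlorophenyl group held, (pentan-3-yl)amino in place of 2-ethylbutyl on an aromatic carbon gives a 1.3-fold higher number from compound 1 to compound 3 (0.12 log units; within the scatter) in this assay. The entering group brings a nitrogen, a hydrogen-bond donor and a hydrogen-bond acceptor that the leaving group lacks, at an equal heavy-atom count, and the two half-lives still stand within the scatter of each other, so this exchange alone shows no readable step at this position. No supporting measurement is available to explain this result.

The compounds shown leave open whether the same exchange reads alike with the substituted phenyl group of compound 2. They also leave open how this position answers to a group of another kind, such as a morpholine or a carboxylic acid, and whether any change here can carry the half-life beyond the scatter of compound 1.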